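Ring Size on the Imino Nitrogen and Adenosine Receptor Binding

The source may hold more compounds than are shown below. What is called first, only, known or untested is meant among the compounds shown, and "the series" means these compounds.

Compound 1 `CCC/N=C(\S)OC[C@H]1OC(n2cnc3c(NC4CCOC4)ncnc32)[C@H](O)[C@@H]1O`: 50 nM
Compound 2 `O[C@@H]1[C@@H](CO/C(S)=N/C2CC2)OC(n2cnc3c(NC4CCOC4)ncnc32)[C@@H]1O`: 157 nM

Among the measured compounds shown here, in an assay on DDT1 cells (Cricetulus griseus) for binding affinity to adenosine receptor A1 (Homo sapiens), read by radioligand binding (on this read-out lower numbers stand for stronger inhibition and higher numbers for weaker inhibition), compound 2 gives 157 nM, the higher of the two numbers measured so far, while compound 1 gives 50 nM. Compound 3 `O[C@@H]1[C@@H](CO/C(S)=N/C2CCC2)OC(n2cnc3c(NC4CCOC4)ncnc32)[C@@H]1O` differs from compound 2 by cyclobutyl in place of cyclopropyl on a double-bonded nitrogen. For the measured compounds named here, only one measured step bears on this change: a 3.1-fold higher number from compound 1 to compound 2 (0.50 log units; beyond the scatter), which was modest. Going from a three-membered to a four-membered ring is a smaller change than that step, so only a small move, if any beyond the scatter, is expected, leaning toward a lower number. Compound 3 is therefore estimated at 100 nM, within 40 nM to 250 nM, an expected step of a 1.6-fold lower number from compound 2 to compound 3 (0.20 log units; within the scatter).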

Compound 3, inhibition constant: 148 nM
Compound 3: the middle estimate sits 1.5-fold (0.17 log units) below what was measured; measured number inside the range.
By their numbers in this assay, from the lowest: compound 1; then compounds 3 and 2 (each within the scatter of the next).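

In this assay, enlarging the ring on the double-bonded nitrogen from cyclopropyl to cyclobutyl gives a 1.1-fold lower number from compound 2 to compound 3 (0.03 log units; within the scatter), so this ring-size change makes no readable difference. The cyclobutyl ring also stays apart from the open propyl chain, with a 3.0-fold higher number from compound 1 to compound 3 (0.47 log units; beyond the scatter), as cyclopropyl did, so among these three compounds both rings differ from propyl. Nothing measured here explains these results. From the compounds shown here alone, whether a larger ring such as cyclopentyl would stay with these two rings remains open. So does whether a longer chain such as butyl would stay close to propyl.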